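From carbamoylamino to benzamido: expectation for compound 4

A few compounds are considered here, and "the series" means these few. Any claim that something is new, unique, unknown or untested is made for them only; others in the source may bear on it.

Three compounds of the series have numbers in a functional assay on SF-295 cells (Homo sapiens) for inhibition, read by sulforhodamine B assay, with a stated time of 48 h; a higher number here means a weaker inhibitor of growth, a lower number a stronger inhibitor of growth. Compound 1 `O=C(Nc1cccc(-n2cc(-c3ccncc3)c(-c3ccc(Cl)c(O)c3)n2)c1)Nc1cccc(C(F)(F)F)c1` gives 962 nM. For the measured compounds named here, compound 3 `O=C(Nc1cccc(-n2cc(-c3ccncc3)c(-c3ccc(Cl)c(O)c3)n2)c1)Nc1cc(C(F)(F)F)cc(C(F)(F)F)c1` gives 618 nM; the step of a 1.6-fold lower number from compound 1 to compound 3 (0.19 log units; within the scatter) is the only measured step between neighbours that differ in one place. Compound 2 `COc1cc(-c2nn(-c3cccc(NC(=O)Nc4ccc(Cl)c(Cl)c4)c3)cc2-c2ccncc2)ccc1Cl` gives 691 nM and stands second highest of the three, nearest compound 3 and furthest from compound 1, both gaps within the scatter, so the three numbers sit together.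

Compound 4 `COc1cc(-c2nn(-c3cccc(NC(=O)c4ccccc4)c3)cc2-c2ccncc2)ccc1Cl` is not yet measured. It differs from compound 2 by phenyl in place of (3,4-dichlorophenyl)amino on a carbonyl carbon; cut one bond further out, the change reads ((3,4-dichlorophenyl)carbamoyl)amino to benzamido. Going by the values given here, no measured step touches this part of the molecule: the one step on record, a 1.6-fold lower number from compound 1 to compound 3 (0.19 log units; within the scatter), alters a different part of the shared core and stays within the scatter, so it says little about replacing the (3,4-dichlorophenyl)amino group. The change is larger in kind than anything measured here, and the expectation rests on that alone. A step toward a higher number, beyond the scatter but with wide uncertainty, is expected: a 2.2-fold higher number from compound 2 to compound 4 (0.34 log units; beyond the scatter). Compound 4 is therefore estimated at 1500 nM, with a range from 500 nM to 5000 nM.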

Compound 4, concentration for 50% growth inhibition: 337 nM
Compound 4: middle estimate off by 4.5-fold (0.65 log units), on the high side; measured number below the stated range.
By their numbers in this assay, from the lowest: compounds 4, 3, 2 and 1 (each within the scatter of the next, the first and the last beyond it).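

For the compounds shown here, replacing (3,4-dichlorophenyl)amino with phenyl on the carbonyl carbon, which turns ((3,4-dichlorophenyl)carbamoyl)amino into benzamido, gives in this assay a 2.1-fold lower number from compound 2 to compound 4 (0.31 log units; beyond the scatter) as the first measured step at this position, and it is modest. Growth inhibition in this assay therefore does not depend, for this pair on this core, on keeping the amino group on the carbonyl carbon or the two chlorines, since compound 4 has neither and still ranks lower in number than compound 2. Nothing at hand accounts for the direction of this step.

Going by these compounds alone, the single step removes the amino nitrogen and both chlorines together, so their shares cannot be separated; 3,4-dichlorobenzamido and (phenylcarbamoyl)amino would be the two compounds that divide them. Also open, from the compounds shown here alone, are whether the same change holds on the core of compound 1, and how the benzamido phenyl responds to trifluoromethyl, to an amine such as morpholine or to a carboxylic acid.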